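Removing the Ethyl Arm: What Compound 3 May Give

The compounds below may be only part of what the source reports. "The series", "measured", "known", "first", "only" and "open" are said of these compounds alone.

Two compounds have been measured:

Compound 1, `CCC(c1cc(-c2ccc(F)c(F)c2)cs1)n1ccnc1`: 68%
Compound 2, `c1ccc(-c2ccc(Cn3ccnc3)cn2)cc1`: 4%

The read-out is an assay for inhibition of steroid 17-alpha-hydroxylase/17,20 lyase (Homo sapiens), using NADPH, tested at 2 uM; on this read-out higher numbers stand for a stronger effect at the one concentration tested and lower numbers for a weaker effect. Compound 1 stands highest of the two numbers; the nearest, compound 2, lies well below it, and that gap is beyond the usual scatter of repeated measurements. Compound 2 differs from compound 1 in several places at once, so its low value is noted here only as a value, not as a lesson about any one change.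

Compound 3, `Fc1ccc(-c2csc(Cn3ccnc3)c2)cc1F`, is not yet measured. It differs from compound 1 in one spot: hydrogen in place of ethyl on a saturated chain carbon bound to an aromatic carbon and an aromatic nitrogen. The chain is simply gone, leaving a hydrogen on that carbon, and everything else in compound 1 stays the same.

Among the compounds with values here, with no measured pair that isolates this change, the expected step is uncertain. It is expected to point downward, since the ethyl is part of what compound 1 carries at the position where compound 3 carries only hydrogen, and the estimated step is a number 38 percentage points lower from compound 1 to compound 3 (beyond the scatter). Compound 3 is thus expected to give 30%, in the range 5% to 60%.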

Compound 3, a percentage reported as inhibition, at one concentration (the size of the read-out at that concentration, not a potency): 25%
Estimate against measurement, compound 3: 5 percentage points above, within the range that was stated.
By their numbers in this assay, from the lowest: compound 2; then compound 3; then compound 1.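

Replacing the ethyl with hydrogen gives a number 43 percentage points lower from compound 1 to compound 3 (beyond the scatter) in this assay. Within the data shown here, this is the first step here that isolates one change. Compound 1 and compound 3 differ only on the saturated chain carbon bound to an aromatic carbon and an aromatic nitrogen. It shows that this position affects the read-out and that the ethyl adds to the effect seen at the one concentration tested, while compound 3, at 25%, keeps part of that effect without the ethyl. Nothing measured here bears on why the ethyl has an effect of this size.

What the compounds shown leave open is how the read-out depends on the group at this carbon: a methyl, a longer chain such as propyl, or an amine could each fall anywhere relative to the ethyl and the hydrogen. Going by these compounds, the step also describes the size of the effect at one concentration and not a potency, so how far compound 1 and compound 3 differ across a range of concentrations remains unknown.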